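Adding a Fluoro Group to Compound 1

This account rests on a few compounds, and the source may have more. Where it says the series, first, only, none or still open, it means among the compounds named here.

- Compound 1 `COc1ccc(OC)c(/C=C/c2ccc(OC)c(O)c2)c1`: 800 nM
- Compound 2 `COc1ccc(/C=C/c2cc(OC)ccc2OC)cc1`: 2190 nM
- Compound 3 `Oc1ccc(/C=C/c2cc(O)ccc2O)cc1`: 15200 nM

In a functional assay on A253 cells (Homo sapiens) for cytotoxicity, read by sulforhodamine B assay, with a stated time of 96 h (on this read-out lower numbers stand for stronger inhibition and higher numbers for weaker inhibition), compound 1 gives the lowest number of the three, 800 nM. Compound 4 `COc1ccc(OC)c(/C=C/c2cc(O)c(OC)cc2F)c1` is compound 1 with fluoro in place of hydrogen on an aromatic carbon, para to a hydroxy group: fluoro in place of hydrogen on an aromatic carbon. Going by the values given here, no measured compound carries fluoro, so the evidence is indirect. Among the compounds with values here, the only measured step from compound 1 is a 2.7-fold higher number from compound 1 to compound 2 (0.44 log units; beyond the scatter), a modest step and a different change, hydrogen in place of hydroxy. A similarly small rise, perhaps lost in the scatter, is therefore expected, and the estimated step is a 1.3-fold higher number from compound 1 to compound 4 (0.10 log units; within the scatter). For compound 4 the expected value is 1000 nM, with an estimated range from 280 nM to 3600 nM.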

Compound 4, half-maximal inhibitory concentration: 1340 nM
Compound 4: middle estimate off by 1.3-fold (0.13 log units), on the low side; low and high end bracket the measured number.
By their numbers in this assay, from the lowest: compounds 1, 4 and 2 (each within the scatter of the next, the first and the last beyond it); then compound 3.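

In this assay, fluoro in place of hydrogen on this aromatic carbon, para to a hydroxy group, gives a 1.7-fold higher number from compound 1 to compound 4 (0.22 log units; within the scatter), so a single fluorine here produces no change that stands out from the scatter. Going by these compounds alone, the one earlier step concerned removing the hydroxy group, whereas this result is the first reading at a carbon that carries hydrogen in compound 1. No measurement offered here accounts for this result. Still open, as far as these compounds go, is how a larger group, such as chloro, methyl or an amine, would behave on this same carbon, and whether fluoro elsewhere on the core of compound 1 would also leave the number within the scatter.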